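Replacing methoxy with a selenium group

This account rests on a few compounds, and the source may have more. Where it says the series, first, only, none or still open, it means among the compounds named here.

In a functional assay on HeLa cells (Homo sapiens) for antiproliferative activity, read by MTT assay, with a stated time of 48 h (a lower number here means a stronger inhibitor, a higher number a weaker inhibitor), compound 1 (`COc1ccc(N(C)c2cc(C)nc(C)n2)cc1`) gives 322 nM. That is level with compound 2 (`COc1ccc(N(C)c2cc(C)nc(C)n2)cc1Cl`) at 316 nM, while compound 3 (`COc1ccc(N(C)c2cc(C)nc(C)n2)cc1[N+](=O)[O-]`) reads 3720 nM. Compound 4 (`C[Se]c1ccc(N(C)c2cc(C)nc(C)n2)cc1`) trades the methoxy of compound 1 for a group of 2 heavy atoms (1 carbon, 1 selenium; no ring), on an aromatic carbon para to a large group: a group of 2 heavy atoms (1 carbon, 1 selenium; no ring) in place of a group of 2 heavy atoms (1 carbon, 1 oxygen; no ring), on an aromatic carbon. Among the compounds with values here, no measured step touches the methoxy itself. The chloro step, a 1.0-fold lower number from compound 1 to compound 2 (0.01 log units; within the scatter), and the nitro step, a 12-fold higher number from compound 1 to compound 3 (1.06 log units; beyond the scatter), each replace a hydrogen instead, so they guide only loosely. On this thin evidence, no step beyond the scatter is expected in this assay, and the estimated step is a 1.2-fold higher number from compound 1 to compound 4 (0.09 log units; within the scatter). For compound 4 the estimated value is 400 nM, with an expected range of 100 nM to 1600 nM.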

Compound 4, half-maximal inhibitory concentration: 138 nM
Compound 4: the middle estimate sits 2.9-fold (0.46 log units) above what was measured, within the range that was stated.
By their numbers in this assay, from the lowest: compound 4; then compounds 2 and 1 (each within the scatter of the next); then compound 3.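

Within the data shown here, until now no measured step had touched the methoxy on this aromatic carbon para to a large group. In this assay the selenium group gives a 2.3-fold lower number from compound 1 to compound 4 (0.37 log units; beyond the scatter), so this place responds to a change of the group itself, and the stronger result comes with 0 hydrogen-bond acceptors in the group where methoxy has 1. No measurement shown here explains the change. Open, going by these compounds, is whether a methylthio group, with sulfur in place of selenium, or a longer chain on selenium such as ethylseleno would match compound 4.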